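The source may hold more compounds than are shown below. What is called first, only, known or untested is meant among the compounds shown, and "the series" means these compounds.

Measured in a functional assay on BXPC-3 cells (Homo sapiens) for inhibition, read by MTT assay, with a stated time of 7 days; a higher number here means a weaker inhibitor, a lower number a stronger inhibitor:

Compound 1 `CCOC(=O)[C@@H]1CCC[C@@H](S(=O)(=O)c2ccc(S(=O)(=O)N(CC)CC)cc2)C1`: 18500 nM
Compound 2 `CCOC(=O)N1CCC[C@H](S(=O)(=O)c2ccc(S(=O)(=O)N(CC)CC)cc2)C1`: > 30000 nM

Compound 1 has a true reading, and that number is high, which marks a weak inhibitor. For compound 2 the entry > 30000 nM is a limit of the assay and not a number. Its position is therefore known from one side only, and no exact figure exists to build on.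

The next compound is compound 3 `CCOC(=O)N1CCC[C@@H](S(=O)(=O)c2ccc(S(=O)(=O)N(CC)CC)cc2)C1`. It is made of the same parts as compound 2, and the one difference lies in how a single centre is drawn: the two compounds have the same atoms and bonds and differ only in configuration as drawn: 1 of 1 stereo elements differ; a stereocentre at a saturated ring carbon is drawn S in compound 2 and R in compound 3. Going by the values given here, no measured pair here shows what such a swap does in this assay. The expectation is no step beyond the scatter in either direction, and a second reading at the limit is quite possible. Among the compounds with values here, the only numeric reading, compound 1 at 18500 nM, gives no hint of a strong inhibitor in this group. The expected change is a number no higher from compound 2 to compound 3 (the limit leaves the size open). Compound 3 is estimated at 30000 nM, with an expected range of 12000 nM to 60000 nM.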

Compound 3, half-maximal inhibitory concentration: > 30000 nM
Compound 3 ended at the assay's limit; the forecaster's own chance of this, stated with the estimate: 60%; the middle value sits exactly at the limit.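

Compound 2 and compound 3 both stop at a limit of the assay and not at a number, so no step can be read between them: the limit of > 30000 nM in this assay, at which 2 of the 3 values shown sit.

The compounds shown leave open whether the stereocentre, drawn S in compound 2 and R in compound 3, makes any difference to inhibition of these cells.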